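Methoxymethyl on the pyridin-4-yl arm: a rearranged compound 3

The compounds below may be only part of what the source reports. "The series", "measured", "known", "first", "only" and "open" are said of these compounds alone.

Three compounds of the series carry the same amide-linked core and differ only in the aryl group on the five-membered ring. Compound 1 `Cc1cc(-c2noc([C@H](C)NC(=O)c3cc(C(F)(F)F)nn3C)n2)ccn1` gives 165 nM in an assay on T-REx-293 cells for inhibition of potassium channel subfamily T member 1 (Homo sapiens), read by patch clamp; on this read-out lower numbers stand for stronger inhibition and higher numbers for weaker inhibition. Compound 2 `C[C@H](NC(=O)c1cc(C(F)(F)F)nn1C)c1nc(-c2cccnc2)no1` gives 11800 nM in this assay, a step of a 72-fold higher number from compound 1 to compound 2 (1.85 log units; beyond the scatter). Compound 3 `COc1cc(-c2noc([C@H](C)NC(=O)c3cc(C(F)(F)F)nn3C)n2)cc(C)n1` gives 505 nM in this assay, the second highest of the three numbers; the step is a 3.1-fold higher number from compound 1 to compound 3 (0.49 log units; beyond the scatter), and against compound 2 it is a 23-fold lower number from compound 2 to compound 3 (1.37 log units; beyond the scatter).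

Compound 4 `COCc1cc(-c2noc([C@H](C)NC(=O)c3cc(C(F)(F)F)nn3C)n2)ccn1` has the same atoms as compound 3 joined differently: 2-(methoxymethyl)pyridin-4-yl in place of 2-methoxy-6-methylpyridin-4-yl on an aromatic carbon. The pyridin-4-yl attachment of compound 1 and compound 3 is kept, so the large step of a 72-fold higher number from compound 1 to compound 2 (1.85 log units; beyond the scatter) should not recur. Within the data shown here, the step of a 3.1-fold higher number from compound 1 to compound 3 (0.49 log units; beyond the scatter) shows that the methoxy on the ring is not needed for the lowest number; compound 4 removes it but adds methoxymethyl, for which no measured step exists. Compound 4 is therefore expected to land near compound 1 and compound 3, estimated at 250 nM with a range of 80 nM to 800 nM. The expected step is a 2.0-fold lower number from compound 3 to compound 4 (0.31 log units; beyond the scatter), modest and downward if anything.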

Compound 4, half-maximal inhibitory concentration: 322 nM
Beside the measured number, compound 4's estimate is 1.3-fold (0.11 log units) below it, within the range that was stated.
By their numbers in this assay, from the lowest: compounds 1, 4 and 3 (each within the scatter of the next, the first and the last beyond it); then compound 2.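

Methoxy on the saturated chain carbon of the 2-methylpyridin-4-yl arm of compound 1 costs little on this read-out, with a 2.0-fold higher number from compound 1 to compound 4 (0.29 log units; within the scatter) as the step. Rearranging the same atoms gives a 1.6-fold lower number from compound 3 to compound 4 (0.20 log units; within the scatter) as the step, so 2-(methoxymethyl)pyridin-4-yl and 2-methoxy-6-methylpyridin-4-yl are not told apart here, although compound 1 and compound 3 are separated beyond the scatter. The 2-(methoxymethyl)pyridin-4-yl arm also keeps the large gap to the pyridin-3-yl arm, with a 37-fold lower number from compound 2 to compound 4 (1.56 log units; beyond the scatter) as the step.

Still open, on these data alone, is whether a longer chain such as ethoxymethyl, or an amine such as dimethylaminomethyl, would be accepted on that same carbon. No measurement at hand accounts for the sizes of these steps.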